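A few compounds are considered here, and "the series" means these few. Any claim that something is new, unique, unknown or untested is made for them only; others in the source may bear on it.

Measured compounds:
Compound 1: `Cc1ccc(-c2cn(C/C=C3\OC(=O)C(OCc4ccccc4)=C3OCc3ccccc3)nn2)cc1` — in a functional assay on HeLa cells (Homo sapiens) for antiproliferative activity, read by MTT assay, with a stated time of 72 h (on this read-out higher numbers stand for weaker inhibition and lower numbers for stronger inhibition), compound 1 gives 7480 nM.
Compound 2: `COc1ccccc1-c1cn(C/C=C2\OC(=O)C(OCc3ccccc3)=C2OCc2ccccc2)nn1` — in this assay compound 2 gives > 100000 nM, which is a limit of the assay and not a number.

Compound 2 therefore stands only at the edge of what this assay can report: it sits at the limit of > 100000 nM in this assay, at which 1 of the 2 values shown sits, and no exact value for it is known. For the measured compounds named here, the one measured step that bears on this series is an at least 13-fold higher number from compound 1 to compound 2 (1.12 log units; beyond the scatter), and it is large. Compound 3 is `O=C1O/C(=C\Cn2cc(-c3cccc(O)c3)nn2)C(OCc2ccccc2)=C1OCc1ccccc1`, not yet tested. It differs from compound 2 in one place: 3-hydroxyphenyl in place of 2-methoxyphenyl on an aromatic carbon. Because compound 2 is known only through > 100000 nM, the step to compound 3 cannot be fixed from the data; the measured step from compound 1 to compound 2 shows that a change of this group on the shared core can move the number a great deal. Compound 3 is expected to come back into the measurable range, with an estimated step of an at least 3.3-fold lower number from compound 2 to compound 3 (0.52 log units; beyond the scatter). The estimate for compound 3 in this assay is 30000 nM, with a range from 6000 nM to 100000 nM.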

Compound 3, half-maximal inhibitory concentration: 74800 nM
Compound 3: middle estimate off by 2.5-fold (0.40 log units), on the low side; low and high end bracket the measured number.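

In this assay, compound 3 gives 74800 nM, an exact reading, so a 3-hydroxyphenyl group on this aromatic carbon of the five-membered ring still leaves a value that can be measured. Replacing 4-methylphenyl with 3-hydroxyphenyl gives a 10-fold higher number from compound 1 to compound 3 (1.00 log units; beyond the scatter), so this is a second replacement at this position that leaves the number well above that of compound 1. The comparison with 2-methoxyphenyl gives an at least 1.3-fold lower number from compound 2 to compound 3 (0.12 log units; that floor lies within the scatter), and since compound 2 is held only by a limit of the assay and not by a number, no order between these two compounds can be claimed: the limit of > 100000 nM in this assay, at which 1 of the 3 values shown sits.

The compounds shown leave open whether the advantage of compound 1 comes from the methyl group itself or from where it sits on the phenyl ring, since each replacement changes both the group and its place on that ring. Going by these compounds, a 4-methoxyphenyl, a 4-hydroxyphenyl or a phenyl ring carrying an amine or a carboxylic acid would help to separate those two questions, and the shape of the trend at this position remains unknown.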